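A Bromo for Fluoro at the Assay Limit

The source may report more compounds than this note shows. Statements on the series, on what has been measured and on what is new or still open speak of the compounds shown alone.

In a functional assay on MCF7 cells (Homo sapiens) for antiproliferative activity, read by MTT assay, with a stated time of 48 h (a lower number here means a stronger inhibitor, a higher number a weaker inhibitor), compound 1 `COc1cc(-c2cccc3nc(-c4cccc(F)c4)oc23)cc(OC)c1OC` gives > 25000 nM as a limit and not a number. Compound 2 `COc1cc(-c2cccc3nc(-c4ccc(F)cc4)oc23)cc(OC)c1OC` also gives > 25000 nM as a limit, so its standing is known only from that limit. Among the compounds with values here, the one measured step is a step that the two limits leave unreadable from compound 1 to compound 2 and offers no size to carry forward.

Compound 3 `COc1cc(-c2cccc3nc(-c4ccc(Br)cc4)oc23)cc(OC)c1OC` differs from compound 2 by bromo in place of fluoro on an aromatic carbon and the change is bromo in place of fluoro on an aromatic carbon, para to a large group, which turns 4-fluorophenyl into 4-bromophenyl. Within the data shown here, no measured step covers a bromo. Among the measured compounds shown here, the only guide is the limit of > 25000 nM in this assay, at which 2 of the 2 values shown sit, and it holds no measured number.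

For the measured compounds named here, no step of readable size, in either direction, is therefore expected in this assay and compound 3 is expected to stay close to that limit, quite possibly reported as a limit itself. The expected change is a step that the limit leaves unreadable from compound 2 to compound 3 as a rough estimate. For compound 3 the estimate is 30000 nM with a range of 12000 nM to 80000 nM expected for repeat measurements.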

Compound 3, half-maximal inhibitory concentration: > 25000 nM
Compound 3 was reported as a limit; the forecaster's own chance of this, stated with the estimate: 70%; the middle value lies beyond the limit too.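

Compound 3 is reported in this assay as a limit and not a number, so no step can be read from compound 1 or compound 2 to compound 3: the limit of > 25000 nM in this assay, at which 3 of the 3 values shown sit.

The compounds shown leave open whether any change to the halogen on the phenyl group, or to the shared core, would give a measurable value in this assay.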